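This account rests on a few compounds, and the source may have more. Where it says the series, first, only, none or still open, it means among the compounds named here.

In a functional assay on MCF7 cells (Homo sapiens) for inhibition, read by microscopy and colony formation, with a stated time of 10 days (a higher number here means a weaker inhibitor, a lower number a stronger inhibitor), compound 1 `CCCCCCCCCCCCCCNC(=O)[C@H](CO)NC(=O)C1CCCCC1` gives 7200 nM, compound 2 `CCCCCCCCCCCCCCNC(=O)[C@H](CO)NCc1ccccc1` gives 5000 nM and compound 3 `CCCCCCCCCCCCCCNC(=O)[C@H](CO)/N=C/c1ccccc1` gives 4700 nM, which places compound 1 level with both within the scatter. Compound 4 `CCCCCCCCCCCCCCNC(=O)[C@H](CO)NC(=O)c1cc(OC)cc(OC)c1` keeps the core of compound 1 and differs by 3,5-dimethoxyphenyl in place of cyclohexyl on a carbonyl carbon. The measured steps that bear on this are a 1.4-fold lower number from compound 1 to compound 2 (0.16 log units; within the scatter), a 1.5-fold lower number from compound 1 to compound 3 (0.19 log units; within the scatter) and a 1.1-fold lower number from compound 2 to compound 3 (0.03 log units; within the scatter). None of them keeps the carbonyl while exchanging the ring, so the evidence is indirect. No change beyond the scatter is expected in this assay, in either direction, and the expected step is a 1.3-fold lower number from compound 1 to compound 4 (0.12 log units; within the scatter). Compound 4 is estimated at 5500 nM, with an expected range of 2200 nM to 12000 nM.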

Compound 4, half-maximal inhibitory concentration: 11200 nM
For compound 4 the middle estimate is 2.0-fold (0.31 log units) below the measured one, within the range that was stated.
By their numbers in this assay, from the lowest: compounds 3, 2, 1 and 4 (each within the scatter of the next, the first and the last beyond it).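

With the carbonyl kept, 3,5-dimethoxyphenyl in place of cyclohexyl gives in this assay a 1.6-fold higher number from compound 1 to compound 4 (0.19 log units; within the scatter), so the ring on this carbonyl carbon can be exchanged without a change beyond the scatter. The earlier steps shown here all altered the carbonyl as well, and this one shows the ring exchange alone. Nothing measured here offers an explanation for this result. The compounds shown leave open how a plain phenyl or a carboxylic acid on the ring would read on this carbonyl carbon, and whether a shorter chain would alter the picture.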